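Chain lengthening on the hydroxamate series

The compounds below may be only part of what the source reports. "The series", "measured", "known", "first", "only" and "open" are said of these compounds alone.

Compound 3 `C=CCCC(=O)NCCCN1CCc2nc(C(=O)NO)sc2C1` gives 58700 nM in an in vitro assay on cells for inhibition of protein deacetylase HDAC6 (Homo sapiens), read by fluorescence, with a stated time of 3 h (a higher number here means a weaker inhibitor, a lower number a stronger inhibitor), the highest of the three numbers shown. Compound 1 `C=CCCC(=O)Nc1ccc(C(=O)N2CCc3nc(C(=O)NO)sc3C2)cc1` gives 390 nM and compound 2 `COc1ccc(/C=C/C(=O)Nc2ccc(C(=O)N3CCc4nc(C(=O)NO)sc4C3)cc2)cc1` gives 450 nM in this assay, both far below compound 3. Compound 4 `C=CCCC(=O)NCCCCN1CCc2nc(C(=O)NO)sc2C1` carries (((but-3-en-1-yl)carbonyl)amino)methyl in place of ((but-3-en-1-yl)carbonyl)amino on a saturated chain carbon, three bonds along the chain from an amine nitrogen in a ring. Among the measured compounds shown here, the single measured step, a 1.2-fold higher number from compound 1 to compound 2 (0.06 log units; within the scatter), concerns the amide substituent of the aryl series and does not test a lengthening of the chain; no measured pair tests this change. With nothing to point either way, the expected step is a 1.1-fold lower number from compound 3 to compound 4 (0.03 log units; within the scatter), not beyond the scatter. Compound 4 is therefore estimated at 55000 nM in this assay, within a range of 18000 nM to 170000 nM.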

Compound 4, half-maximal inhibitory concentration: 24800 nM
Beside the measured number, compound 4's estimate is 2.2-fold (0.35 log units) above it, within the range that was stated.
By their numbers in this assay, from the lowest: compounds 1 and 2 (each within the scatter of the next); then compound 4; then compound 3.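

In this assay, the saturated chain carbon three bonds along the chain from an amine nitrogen in a ring responds to the added methylene of (((but-3-en-1-yl)carbonyl)amino)methyl (a 2.4-fold lower number from compound 3 to compound 4 (0.37 log units; beyond the scatter)). Among the compounds shown here, this is the first step that bears on the chain itself rather than on the amide substituent, and it is modest. Nothing available accounts for the step.

As far as these compounds go, whether a longer chain lowers the number further remains open, as one step gives no trend. Also open, from the compounds shown here alone, is whether 2-(4-methoxyphenyl)ethenyl in place of but-3-en-1-yl on this chain leaves the number as unchanged as it does in the aryl series.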